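Swapping chloro for dimethylsulfamoyl: a cytotoxicity estimate

This account rests on a few compounds, and the source may have more. Where it says the series, first, only, none or still open, it means among the compounds named here.

Compound 1, `CN1CCN(CCNCc2cn(-c3ccc(F)cc3F)nc2-c2ccc(Cl)cc2)CC1`: 19000 nM
Compound 2, `CN1CCN(CCCNCc2cn(-c3ccc([N+](=O)[O-])cc3)nc2-c2ccc(C(F)(F)F)cc2)CC1`: 4900 nM
Compound 3, `CN1CCN(CCNCc2cn(-c3ccc(C(F)(F)F)cc3)nc2-c2ccc(Cl)cc2)CC1`: 3000 nM

All three were tested in an ADME assay on Huh-7 cells (Homo sapiens) for cytotoxicity; a higher number here means that more compound is tolerated, a lower number that less compound is tolerated. Compound 1 stands highest of the three, with compound 2 and compound 3 both below it. Within the data shown here, the only single-point change measured among them is a 6.3-fold lower number from compound 1 to compound 3 (0.80 log units; beyond the scatter), which concerns the ring on the aromatic nitrogen.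

Compound 4, `CN1CCN(CCNCc2cn(-c3ccc(F)cc3F)nc2-c2ccc(S(=O)(=O)N(C)C)cc2)CC1`, differs from compound 1 by dimethylsulfamoyl in place of chloro on an aromatic carbon. Among the measured compounds shown here, no measured step touches this part of the molecule, so the one recorded step does not bear on it. With nothing to indicate a direction, the step is expected to stay within the scatter: a 1.1-fold higher number from compound 1 to compound 4 (0.02 log units; within the scatter). Compound 4 is therefore estimated at 20000 nM, with a range from 7000 nM to 60000 nM.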

Compound 4, half-maximal cytotoxic concentration: > 20000 nM
Compound 4 ended at the assay's limit; the forecaster's own chance of this, stated with the estimate: 15%; the middle value lies on the limit itself.
By their numbers in this assay, from the lowest: compounds 3 and 2 (each within the scatter of the next); then compound 1. At a limit, above all of these: compound 4.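

Among these compounds, no earlier step touched this position, and in this assay dimethylsulfamoyl in place of chloro gives an at least 1.0-fold higher number from compound 1 to compound 4 (0.02 log units; that floor lies within the scatter). Compound 4 has no exact number, only a limit: the limit of > 20000 nM in this assay, at which 1 of the 4 values shown sits. Swapping the single chlorine atom for dimethylsulfamoyl therefore brought no fall in the tolerated concentration, though how far the number rises cannot be read.

Going by these compounds, whether a methoxy group or a primary amine at this position would behave the same stays open. So does whether dimethylsulfamoyl would give the same result alongside the other ring of compound 3.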